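Methoxy for acetamido: HepG2 cytotoxicity of compound 4

A few compounds are considered here, and "the series" means these few. Any claim that something is new, unique, unknown or untested is made for them only; others in the source may bear on it.

Compound 3 `CCOC(=O)CCCCCOc1cccc(CN(C(=O)c2ccc(-c3cccc(NC(C)=O)c3)cc2)C(C)C)c1` in an ADME assay on HepG2 cells (Homo sapiens) for cytotoxicity, read by CellTiter-Glo and resazurin assay, with a stated time of 72 h (a higher number here means that more compound is needed for the effect, a lower number that less compound is needed), gives only a limit, > 26000 nM. Compound 1 `CC(=O)Nc1cccc(-c2ccc(C(=O)N(Cc3cccc(OCCCCCC(=O)O)c3)C(C)C)cc2)c1` likewise gives a limit in this assay, > 26000 nM. Compound 2 `CC(C)N(Cc1cccc(OCCCCCC(=O)O)c1)C(=O)c1ccc(-c2c[nH]c3ccccc23)cc1` also stops at a limit, > 26000 nM. Both a step that the two limits leave unreadable from compound 1 to compound 3 and a step that the two limits leave unreadable from compound 1 to compound 2 are therefore steps without a size. That follows because of the limit of > 26000 nM in this assay, at which 3 of the 3 values shown sit. Compound 4 `CCOC(=O)CCCCCOc1cccc(CN(C(=O)c2ccc(-c3cccc(OC)c3)cc2)C(C)C)c1` differs from compound 3 by methoxy in place of acetamido on an aromatic carbon. Within the data shown here, of the measured steps, the one from compound 1 to compound 2 also alters the 3-acetamidophenyl group and the one from compound 1 to compound 3 ends in compound 3, yet neither yields a readable size. No step beyond the scatter is expected for compound 4, and a limit once more seems the likeliest outcome. Compound 4 is expected at 26000 nM, within 13000 nM to 60000 nM. The estimated step is a number no higher from compound 3 to compound 4 (the limit leaves the size open), essentially flat.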

Compound 4, half-maximal effective concentration: > 21000 nM
Compound 4: a limit, no number (the forecaster's own chance of this, stated with the estimate: 80%); the middle value lies beyond the limit too.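

Compound 3 and compound 4 both stop at limits, so no size can be read for methoxy in place of acetamido. The compounds shown leave open at what concentration any of them reaches the half-maximal effect.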